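From a Cyclohexyl Ring to an Isopropoxy Chain

A few compounds are considered here, and "the series" means these few. Any claim that something is new, unique, unknown or untested is made for them only; others in the source may bear on it.

Compound 1, `Nc1ccc2cccc(OCCC3CCCCC3)c2n1`, was tested in an assay on cells with melanin-concentrating hormone receptor 1 (Homo sapiens) as the target, read by radioligand binding (a higher number here means a weaker inhibitor, a lower number a stronger inhibitor), where compound 1 gives 808 nM. Among the compounds with a number, compound 1 has the highest one; the nearest is compound 2, `CC(C)C(C)Oc1cccc2ccc(N)nc12`, which in this assay gives 199 nM. Compound 3, `CC#CCCOc1cccc2ccc(N)nc12`, reaches only the limit of this assay, and for compound 3 the value > 2000 nM is a limit rather than a number (the limit of > 2000 nM in this assay, at which 1 of the 3 values shown sits).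

Compound 4, `CC(C)OCCOc1cccc2ccc(N)nc12`, differs from compound 1 in one place: isopropoxy in place of cyclohexyl on a saturated chain carbon, two bonds along the chain from an oxygen on an aromatic ring. The step that bears most directly on this change sits at the same place in the chain, an at least 2.4-fold higher number from compound 1 to compound 3 (0.39 log units; beyond the scatter), where trading the ring on the chain for a group with a triple bond weakened binding. The other measured step, an at least 10-fold higher number from compound 2 to compound 3 (1.00 log units; beyond the scatter), also ended at the limit. Every change so far that moved away from the chains of compound 1 and compound 2 gave weaker binding, so compound 4 is expected to be weaker than compound 1, with an estimated step of a 3.1-fold higher number from compound 1 to compound 4 (0.49 log units; beyond the scatter). In this assay compound 4 is estimated at 2500 nM, expected to lie between 800 nM and 8000 nM, and it may well return only a limit.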

Compound 4, half-maximal inhibitory concentration: > 2000 nM
Compound 4: only a limit was reported (the forecaster's own chance of this, stated with the estimate: 50%); the middle value lies beyond the limit too.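

Replacing cyclohexyl with isopropoxy at this place on the chain gives an at least 2.4-fold higher number from compound 1 to compound 4 (0.39 log units; beyond the scatter) in this assay, so a chain end carrying an oxygen, like the one carrying a triple bond in compound 3, reaches only a limit, while the ring of compound 1 gives a number. Set against the 1,2-dimethylpropyl group of compound 2, the 2-isopropoxyethyl group gives an at least 10-fold higher number from compound 2 to compound 4 (1.00 log units; beyond the scatter), which shows that the loss also holds when the whole group on the aromatic oxygen is exchanged. The result for compound 4 is a limit and not a number, and compound 3 also has a limit, so the step between them cannot be read and the two groups cannot be ranked: the limit of > 2000 nM in this assay, at which 2 of the 4 values shown sit.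

Among the compounds shown, cyclohexyl is the only group at this place on the chain that gives a number, so it remains open whether a ring as such is what matters or whether other groups could serve as well. A cyclopentyl or phenyl ring at the same place would bear on that question, and an amine at the chain end would test a quite different kind of group there.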